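The compounds below may be only part of what the source reports. "The series", "measured", "known", "first", "only" and "open" are said of these compounds alone.

Measured compounds:
compound 1 `CCC(=O)Nc1cccc(S(=O)(=O)N2CCC(NC(=O)c3n[nH]cc3NC(=O)c3c(Cl)cccc3Cl)CC2)c1` in an assay on HEK293 cells for inhibition of cyclin-dependent kinase 14 (Homo sapiens), with a stated time of 4 h (a lower number here means a stronger inhibitor, a higher number a weaker inhibitor), gives > 1000 nM;
compound 2 `CCC(=O)Nc1cccc(CN2CCC(NC(=O)c3n[nH]cc3NC(=O)c3c(Cl)cccc3Cl)CC2)c1` gives > 1000 nM;
compound 3 `CN(C)CC/C=C/C(=O)Nc1ccc(S(=O)(=O)N2CC[C@@H](NC(=O)c3n[nH]cc3NC(=O)c3c(Cl)cccc3Cl)C2)cc1` gives > 1000 nM.

Each of these readings is a limit of this assay, not a number, and compound 1 therefore stands only at that limit, as do both other compounds shown (the limit of > 1000 nM in this assay, at which 3 of the 3 values shown sit). Among the compounds with values here, no step between measured compounds can be read from them. Compound 4 `C=CC(=O)Nc1cccc(S(=O)(=O)N2CCC(NC(=O)c3n[nH]cc3NC(=O)c3c(Cl)cccc3Cl)CC2)c1` differs from compound 1 by vinyl in place of ethyl on a carbonyl carbon. With nothing to compare beyond three limits, the direction of the step is uncertain, but a move to a measurable number is considered possible; the step from compound 1 to compound 4 is expected at an at least 4.0-fold lower number from compound 1 to compound 4 (0.60 log units; beyond the scatter). Compound 4 is estimated at 250 nM, within 25 nM to 2500 nM.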

Compound 4, half-maximal inhibitory concentration: 1000 nM
Estimate against measurement, compound 4: 4.0-fold (0.60 log units) below; the range from low to high includes it.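

In this assay, vinyl in place of ethyl on a carbonyl carbon gives a number no higher from compound 1 to compound 4 (the limit leaves the size open). Compound 4 gives 1000 nM, the only number among the compounds shown, so this position now has one reading that is not a limit. The other compounds shown give no number: the limit of > 1000 nM in this assay, at which 3 of the 4 values shown sit.

Going by these compounds, how far compound 4 truly lies from compound 1 stays open, since the limit hides the size of the step. Also open, on these data alone, is whether an ethynyl group or a longer chain on this carbonyl carbon would move the number in either direction.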